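This account rests on a few compounds, and the source may have more. Where it says the series, first, only, none or still open, it means among the compounds named here.

Compound 1, `COc1cc(CN(C)C(=O)c2c(OCCCC3CCN(C(=O)OC(C)(C)C)CC3)c3ccccc3n(C)c2=O)cc(OC)c1`, gives 91 nM in an assay on cells for inhibition of phosphatidylcholine:ceramide cholinephosphotransferase 2 (Homo sapiens), read by mass spectrometry, with stated times of 60 min and 30 min; on this read-out higher numbers stand for weaker inhibition and lower numbers for stronger inhibition.
Compound 2, `CCCOc1c(C(=O)N(C)Cc2cc(C(F)(F)F)cc(C(F)(F)F)c2)c(=O)n(C)c2ccccc12`, gives 2100 nM in this assay.
Compound 3, `COc1cc(CN(C)C(=O)c2c(OCCCC3CCN(C(=O)OC(C)(C)C)CC3)c3cnccc3n(C)c2=O)cc(OC)c1`, gives 1600 nM in this assay.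

Among these three, compound 2 has the highest number, meaning the weakest inhibition. Compound 3 lies nearest, within the usual scatter, so no order can be drawn between compound 2 and compound 3. Compound 1 lies furthest, beyond the scatter, with a clearly lower number than compound 2.

Compound 4, `CN(Cc1cc(C(F)(F)F)cc(C(F)(F)F)c1)C(=O)c1c(N2CCCCC2)c2ccccc2n(C)c1=O`, is not yet measured. It differs from compound 2 in one place: piperidin-1-yl in place of propoxy on an aromatic carbon. Among the measured compounds shown here, no measured pair shows this change, so its size cannot be read from the data. The expected step is a 1.4-fold lower number from compound 2 to compound 4 (0.15 log units; within the scatter), which is nothing beyond the scatter. Compound 4 is expected to give about 1500 nM, within a range from 400 nM to 6000 nM.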

Compound 4, half-maximal inhibitory concentration: 11000 nM
Beside the measured number, compound 4's estimate is 7.3-fold (0.87 log units) below it; the measured number lies above the stated range.
By their numbers in this assay, from the lowest: compound 1; then compounds 3 and 2 (each within the scatter of the next); then compound 4.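

At this aromatic carbon, opposite the ring nitrogen, the attached group matters: in this assay, piperidin-1-yl in place of propoxy gives a 5.2-fold higher number from compound 2 to compound 4 (0.72 log units; beyond the scatter) and so weaker inhibition. Among the compounds shown here, this is the first single-place change that can be read, and it lies beyond the usual scatter. Nothing available bears on why this step occurs.

Still open, from the compounds shown here alone, is whether the step follows the ring or the nitrogen that joins it to the core. A cyclohexyloxy group, which keeps the oxygen link, and a dimethylamino group, which keeps the nitrogen without a ring, would each test one of these.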